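The source may report more compounds than this note shows. Statements on the series, on what has been measured and on what is new or still open speak of the compounds shown alone.

Measured compounds:
Compound 1 `O=S(=O)(NC1=NCCN1C(=S)SN1CCn2c1nsc2=S)c1cccc(OC(F)(F)F)c1` gives >= 20000 nM in a functional assay on KYSE-510 cells (Homo sapiens) for antiproliferative activity, read by crystal violet staining, with a stated time of 96 h; on this read-out higher numbers stand for weaker inhibition of growth and lower numbers for stronger inhibition of growth — a limit of the assay, not a number.
Compound 2 `O=S(=O)(NC1=NCCN1C(=S)SN1CCn2c1nsc2=S)c1ccccc1Cl` gives >= 20000 nM in this assay — likewise a limit, not a number.

Among the compounds with values here, compound 2 therefore cannot be placed on a scale at all: its reading is a limit, and the one other reading is a limit of the same kind, so that both values sit at the same point the limit of >= 20000 nM in this assay, at which 2 of the 2 values shown sit, and nothing separates them. Within the data shown here, no step between measured compounds exists here; the two values show only that neither compound reaches measurable growth inhibition within the tested range.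

Compound 3 `O=S(=O)(NC1=NCCN1C(=S)SN1CCn2c1nsc2=S)c1cccc(Cl)c1` is the next member to be measured in this assay. Its change from compound 2 is 3-chlorophenyl in place of 2-chlorophenyl on a sulfonyl sulfur. Among the measured compounds shown here, with both neighbours at the limit there is no measured step to lean on, and the change keeps the same atoms in a different arrangement, so no movement beyond the scatter is expected; the step of a number no higher from compound 2 to compound 3 (the limit leaves the size open) is estimated as essentially none, with the reading most likely to remain a limit. Compound 3 is expected at about 20000 nM, within 8000 nM to 40000 nM.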

Compound 3, concentration for 50% growth inhibition: >= 20000 nM
Compound 3: a limit, no number (the forecaster's own chance of this, stated with the estimate: 80%); the middle value sits exactly at the limit.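

No step from compound 1 or compound 2 to compound 3 can be read in this assay, as all three readings stand at one limit rather than at numbers: the limit of >= 20000 nM in this assay, at which 3 of the 3 values shown sit.

The compounds shown leave open how far these three differ from one another, and whether any group on the sulfonyl sulfur brings growth inhibition into the measurable range.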